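The source may hold more compounds than are shown below. What is called first, only, known or untested is meant among the compounds shown, and "the series" means these compounds.

In a functional assay on the whole organism with Mus musculus as the target (a higher number here means that more compound is needed for the effect, a lower number that less compound is needed), compound 2 (`Cc1c(C)c2c(c(C)c1NS(C)(=O)=O)CC(C)(C)O2`) gives > 100 mg/kg, which is a limit of the assay and not a number. Compound 1 (`CC(=O)Nc1c(C)c(C)c2c(c1C)CC(C)(C)O2`) gives > 100 mg/kg, again a limit. Within the data shown here, the only measured step is a step that the two limits leave unreadable from compound 1 to compound 2, so it offers no size to carry forward. The evidence amounts to the limit of > 100 mg/kg in this assay, at which 2 of the 2 values shown sit.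

The next compound, compound 3 (`Cc1c(C)c2c(c(C)c1Nc1cccnc1)CC(C)(C)O2`), changes the same nitrogen, with pyridin-3-yl in place of methylsulfonyl on a nitrogen on an aromatic ring. Among the measured compounds shown here, this exchange differs from the measured one, as the group that enters carries a six-membered aromatic ring with 1 hetero atom, and no measured compound has such a group. The measured step bears on it only by sharing the place of change, and its size cannot be read. A report of only a limit therefore remains more likely than not for compound 3. If a number does appear, a modest shift towards a lower dose is expected, given as an at least 1.2-fold lower number from compound 2 to compound 3 (0.09 log units; that floor lies within the scatter). Compound 3 is estimated at 80 mg/kg, with an expected range from 25 mg/kg to 200 mg/kg.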

Compound 3, dose for 50% inhibition: > 50 mg/kg
Compound 3 gave a limit, no number (the forecaster's own chance of this, stated with the estimate: 60%); the middle value does not contradict the limit.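

In this assay compound 3 gives > 50 mg/kg, which is a limit of the assay and not a number. As compound 1 and compound 2 also stand only as limits, no step among these three compounds can be read. The compounds shown leave open what dose any of them needs for the effect, and whether acetyl, methylsulfonyl and pyridin-3-yl on the nitrogen differ at all.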